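Swapping the Para Group: Methylsulfonyl to Cyano at One Carbon

A few compounds are considered here, and "the series" means these few. Any claim that something is new, unique, unknown or untested is made for them only; others in the source may bear on it.

Compound 1, `Cc1ccc(C2=NN(c3nc(-c4ccc(F)cc4)cs3)C(c3ccc(F)cc3)C2)s1`, gives 125 ug/mL in a functional assay on A549 cells (Homo sapiens) for antiproliferative activity, read by XTT assay, with a stated time of 24 h; a lower number here means a stronger inhibitor, a higher number a weaker inhibitor.
Compound 2, `Cc1ccc(C2=NN(c3nc(-c4ccc([N+](=O)[O-])cc4)cs3)C(c3ccc(F)cc3)C2)s1`, gives 16.7 ug/mL.
Compound 3, `Cc1ccc(C2=NN(c3nc(-c4ccc(S(C)(=O)=O)cc4)cs3)C(c3ccc(F)cc3)C2)s1`, gives > 500 ug/mL, which is a limit of the assay rather than a number.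

Compound 3 is thus the weakest of the three: the step of an at least 4.0-fold higher number from compound 1 to compound 3 (0.60 log units; beyond the scatter) and the step of an at least 29-fold higher number from compound 2 to compound 3 (1.47 log units; beyond the scatter) both ran toward higher numbers. Compound 4, `Cc1ccc(C2=NN(c3nc(-c4ccc(C#N)cc4)cs3)C(c3ccc(F)cc3)C2)s1`, differs from compound 3 at one aromatic carbon: cyano in place of methylsulfonyl on an aromatic carbon. Going by the values given here, no measured step swaps exactly these two groups, but the three measured steps, all at this carbon, show that the group there moves the number widely in both directions, with methylsulfonyl at the weak end. Removing it is therefore expected to lower the number, the estimated step being an at least 8.3-fold lower number from compound 3 to compound 4 (0.92 log units; beyond the scatter). Compound 4 is estimated at 60 ug/mL, with a likely range from 15 ug/mL to 400 ug/mL.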

Compound 4, half-maximal inhibitory concentration: 322 ug/mL
The estimate for compound 4 lay 5.4-fold (0.73 log units) below the measured number; measured number inside the range.
By their numbers in this assay, from the lowest: compound 2; then compound 1; then compound 4. At a limit, above all of these: compound 3.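

Cyano does not share the low number of nitro at this carbon, a 19-fold higher number from compound 2 to compound 4 (1.29 log units; beyond the scatter), and it also sits on the weak side of fluoro, a 2.6-fold higher number from compound 1 to compound 4 (0.41 log units; beyond the scatter). Against methylsulfonyl, an at least 1.5-fold lower number from compound 3 to compound 4 (0.19 log units; that floor lies within the scatter) gives only a floor, so these two groups cannot yet be firmly ordered. Compound 3 carries a limit of the assay rather than a number: the limit of > 500 ug/mL in this assay, at which 1 of the 4 values shown sits.

On these data alone, whether an amine or a carboxylic acid at this carbon would land nearer compound 2 or compound 4 remains open. So does whether this order of groups holds when the rest of the shared core changes.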